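A few compounds are considered here, and "the series" means these few. Any claim that something is new, unique, unknown or untested is made for them only; others in the source may bear on it.

Measured so far in a physicochemical assay for lipophilicity, read by HPLC, in phosphate buffer, measured as octanol-water partition, with a stated time of 1 h, at pH 7.4; on this read-out lower numbers stand for lower lipophilicity and higher numbers for higher lipophilicity:
compound 1 `C[C@@]1(c2cc(NC(=O)c3ncc(OCF)nc3N)ccc2F)C=C(CF)OC(N)=N1` gives 3.1
compound 2 `CC1=COC(N)=N[C@]1(C)c1cc(NC(=O)c2ccc(C#N)cn2)ccc1F` gives 1.5

Compound 2 stands lowest of the two numbers; the nearest, compound 1, lies higher by a gap beyond the scatter. Compound 3 `C[C@@]1(c2cc(NC(=O)c3ccc(C#N)cn3)ccc2F)C=COC(N)=N1` differs from compound 2 in one place: hydrogen in place of methyl on a double-bonded ring carbon. Among the measured compounds shown here, no step of this kind between measured compounds is available. A small fall is expected, probably not beyond the scatter, so the step from compound 2 to compound 3 is estimated at a number 0.30 log units lower from compound 2 to compound 3 (within the scatter). In this assay compound 3 is expected to give 1.2, with a range from 0.8 to 1.6.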

Compound 3, distribution coefficient: 2
Beside the measured number, compound 3's estimate is 0.80 log units below it; the whole stated range lies below it.
By their numbers in this assay, from the lowest: compound 2; then compound 3; then compound 1.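

Among the compounds shown here, this is the first single-place comparison: in this assay, hydrogen in place of methyl on a double-bonded ring carbon gives a number 0.50 log units higher from compound 2 to compound 3 (beyond the scatter). At this position, then, losing the methyl does not lower the number, and the step lies beyond the scatter. No measurement at hand accounts for this rise.

A single pair cannot show whether the step carries over to other amide partners, since compound 1 differs from compound 3 in more than one place. From the compounds shown here alone, how a longer chain such as ethyl, or an amine, would read at this ring carbon remains open.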